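The source may hold more compounds than are shown below. What is called first, only, known or untested is meant among the compounds shown, and "the series" means these compounds.

Measured so far:
- compound 1, `c1ccc(-c2nc[nH]n2)c(NCC2=NCCN2)c1`: 0.794 nM
- compound 2, `CCCn1nccc1-c1ccccc1NCC1=NCCN1`: 251 nM

In an in vitro functional assay on cells (Fibroblast) for agonist activity at Alpha-1A adrenergic receptor (Homo sapiens) (on this read-out higher numbers stand for an effect only at larger amounts of compound and lower numbers for an effect already at smaller amounts), compound 1 gives 0.794 nM, the lower of the two numbers recorded. Compound 2, in which the azole carries a propyl on nitrogen and has lost its hydrogen-bond donor, gives 251 nM in this assay; the two values show compound 2 well above compound 1, a gap beyond the scatter. Among the measured compounds shown here, no step between compounds differing in a single place has been measured, so the two values stand as a pair only.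

Compound 3, `Cn1cccc1-c1ccccc1NCC1=NCCN1`, is not yet measured in this assay. Against compound 1 the change is 1-methyl-1H-pyrrol-2-yl in place of 1H-1,2,4-triazol-3-yl on an aromatic carbon. The group that enters has no hydrogen-bond donor and one acceptor fewer than the group that leaves, which moves compound 3 in the direction of compound 2 on those counts.

The expected step from compound 1 to compound 3 is a 76-fold higher number from compound 1 to compound 3 (1.88 log units; beyond the scatter), toward a higher number, well beyond the scatter, because compound 2 gives 251 nM once the azole hydrogen is replaced by an alkyl group. Compound 3 is therefore estimated at 60 nM in this assay, with a range from 8 nM to 400 nM.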

Compound 3, half-maximal effective concentration: 20 nM
Estimate against measurement, compound 3: 3.0-fold (0.48 log units) above, within the range that was stated.
By their numbers in this assay, from the lowest: compound 1; then compound 3; then compound 2.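

In this assay, among the compounds shown here, replacing 1H-1,2,4-triazol-3-yl with 1-methyl-1H-pyrrol-2-yl on the aromatic carbon ortho to the group of 7 heavy atoms gives a 25-fold higher number from compound 1 to compound 3 (1.40 log units; beyond the scatter) and is the first single-place step read at this position. The position therefore carries real weight in this series, yet a group with 0 hydrogen-bond donors still leaves compound 3 at 20 nM in this read-out. The change alters the ring hetero atoms, the donor and acceptor counts and the heavy-atom count together, so the step cannot be assigned to any one of them, and no measurement on hand accounts for this result.

Still open, on these data alone, is how much of the step follows the methyl on the ring nitrogen and how much follows the loss of ring nitrogens, a question that 1H-pyrrol-2-yl or a methyl-substituted 1,2,4-triazole at the same carbon would separate. Also open, as far as these compounds go, is how a group of another kind at this carbon, such as a primary amine or a carboxylic acid, would fall relative to compound 1 and compound 3.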